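This account rests on a few compounds, and the source may have more. Where it says the series, first, only, none or still open, it means among the compounds named here.

Working notes on the phenylethyl urea series.

Compound 1 `Cc1cccc(NC(=O)N[C@H](C)c2ccccc2)c1` and compound 2 `C[C@@H](NC(=O)Nc1cccc(C(F)(F)F)c1)c1ccccc1` share one core and differ only in a single aromatic substituent. In an ADME assay on the whole organism with Oryza sativa as the target, tested at 10 uM (a higher number here means a weaker effect of the compound at the concentration tested, a lower number a stronger effect), compound 1 gives 47%, while compound 2 gives 70%. Going by the values given here, the step of a number 23 percentage points higher from compound 1 to compound 2 (beyond the scatter) is the only measured step so far. On the two numbers in hand, compound 2 stands highest; the nearest is compound 1, sitting lower by a margin beyond the scatter.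

Compound 3 `CCOC(=O)c1cccc(NC(=O)N[C@H](C)c2ccccc2)c1` is the next member, not yet measured. Relative to compound 2 it carries the change (ethoxycarbonyl in place of trifluoromethyl on an aromatic carbon). Among the compounds with values here, no measured step covers an ethoxycarbonyl group, so only the step from compound 1 to compound 2 bears on it, and it does so only loosely, since it swaps one group for a different third one at the same aromatic carbon. The two measured values bracket a modest range, and there is no basis to place compound 3 outside it. The expectation for this assay is therefore a step of no size beyond the scatter, a number 8 percentage points lower from compound 2 to compound 3 (within the scatter), in either direction. Compound 3 is estimated at 62% in this assay, with a range from 38% to 86%.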

Compound 3, a percentage reported as activity, at one concentration (the size of the read-out at that concentration, not a potency): 88%
Beside the measured number, compound 3's estimate is 26 percentage points below it; the measured number lies above the stated range.
By their numbers in this assay, from the lowest: compound 1; then compound 2; then compound 3.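

Working notes, continued. Going by these compounds alone, at this aromatic carbon, meta to a large group, the spread in this assay is wider than the single methyl to trifluoromethyl step could show: ethoxycarbonyl in place of trifluoromethyl gives a number 18 percentage points higher from compound 2 to compound 3 (beyond the scatter) and ethoxycarbonyl in place of methyl gives a number 41 percentage points higher from compound 1 to compound 3 (beyond the scatter). Compound 3 therefore has the weakest effect of the three at the concentration tested, with both of its steps beyond the scatter, and the three substituents now fall in the order methyl, trifluoromethyl, ethoxycarbonyl from the strongest effect to the weakest. Nothing available explains why the number rises with this change, and the larger group with its two hydrogen-bond acceptors differs from trifluoromethyl in too many counted features at once for any one of them to be singled out.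

The compounds shown leave open whether the rise belongs to the ester as such or would also appear with a carboxylic acid or a simple ketone at the same aromatic carbon. They also leave open whether a methoxycarbonyl group, with a shorter chain on the oxygen, would keep the number of compound 3 or fall back toward that of compound 2.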